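Swapping a Cyclopropyl for an Isopropylamino Group

The source may report more compounds than this note shows. Statements on the series, on what has been measured and on what is new or still open speak of the compounds shown alone.

Among the measured compounds shown here, the three compounds measured so far share one core and differ mainly in the group attached to a sulfonyl sulfur and in the amide at the other end. Compound 1 `CCC(CC)S(=O)(=O)c1ccc(S(=O)(=O)N2CCC[C@@H](C(=O)N3CCC(F)(F)CC3)C2)cc1` gives 40 nM in a functional assay on BXPC-3 cells (Homo sapiens) for inhibition, read by MTT assay, with a stated time of 7 days; on this read-out lower numbers stand for stronger inhibition and higher numbers for weaker inhibition. Compound 2 `O=C([C@@H]1CCCN(S(=O)(=O)c2ccc(S(=O)(=O)C3CC3)cc2)C1)N1CCC(F)(F)CC1` gives 129 nM; the change between them is a 3.2-fold higher number from compound 1 to compound 2 (0.51 log units; beyond the scatter). Compound 3 `CCN(CC)S(=O)(=O)c1ccc(S(=O)(=O)N2CCC[C@@H](C(=O)N3CCC(COC)CC3)C2)cc1` gives 1360 nM, the highest number of the three, but it differs from compound 2 in two places, so no single step can be read from it. Among the numbers shown, compound 2 stands second highest, nearer to compound 1 than to compound 3.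

Compound 4 `CC(C)NS(=O)(=O)c1ccc(S(=O)(=O)N2CCC[C@@H](C(=O)N3CCC(F)(F)CC3)C2)cc1` carries isopropylamino in place of cyclopropyl on a sulfonyl sulfur. For the measured compounds named here, only one measured step bears on this position: the step from compound 1 to compound 2, which was modest in size and moved the number upward. Compound 3 hints that a nitrogen on this sulfonyl sulfur can sit with a high number, though its amide differs too. A step of similar, modest size is therefore expected, toward a higher number, as a 2.3-fold higher number from compound 2 to compound 4 (0.37 log units; beyond the scatter). Compound 4 is estimated at 300 nM, with a range from 90 nM to 1000 nM.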

Compound 4, half-maximal inhibitory concentration: 470 nM
For compound 4 the middle estimate is 1.6-fold (0.19 log units) below the measured one; the measured number falls inside the stated range.
By their numbers in this assay, from the lowest: compound 1; then compound 2; then compound 4; then compound 3.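

The change at this sulfonyl sulfur swaps a three-membered ring of carbon only for an open isopropylamino group that brings in a nitrogen and a hydrogen-bond donor, and in this assay it gives a clear rise in the number, which means weaker inhibition (a 3.6-fold higher number from compound 2 to compound 4 (0.56 log units; beyond the scatter)). Among the compounds shown here, measured against the pentan-3-yl group, the same position gives a large step (a 12-fold higher number from compound 1 to compound 4 (1.07 log units; beyond the scatter)), so with the amide and the rest of the structure held fixed, the choice of this one group alone moves the number widely, and the only one of the three groups that carries a nitrogen gives the highest number. No measurement shown here explains this rise.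

The ring is lost and the nitrogen is gained in the same change, so these compounds cannot tell which of the two matters, or whether both do. A cyclopropylamino group on this sulfonyl sulfur would keep the ring while adding the nitrogen, and a pentan-3-ylamino group would pair the nitrogen with the carbon chain of the compound that gives the lowest number.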